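Replacing Isobutoxy with 4-Aminophenyl on the Carbonyl

The compounds below may be only part of what the source reports. "The series", "measured", "known", "first", "only" and "open" are said of these compounds alone.

Two measured compounds share one core and differ only in the alkyl group on the oxygen of the carbonyl. Compound 1 `CCc1cc(S(=O)(=O)N2C[C@H](c3ccccc3)NC2=O)ccc1NC(=O)OC(C)C` carries isopropyl there, and in a functional assay on NCI-H460 cells (Homo sapiens) for cytotoxicity, read by MTT assay (a higher number here means a weaker inhibitor, a lower number a stronger inhibitor), compound 1 gives 60 nM. Compound 2 `CCc1cc(S(=O)(=O)N2C[C@H](c3ccccc3)NC2=O)ccc1NC(=O)OCC(C)C` carries isobutyl, and in this assay compound 2 gives 80 nM. For the measured compounds named here, the step of a 1.3-fold higher number from compound 1 to compound 2 (0.12 log units; within the scatter) lies within the scatter, so these two values cannot be told apart; compound 2 has the higher of the two numbers, with compound 1 as its only neighbour.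

Compound 3 `CCc1cc(S(=O)(=O)N2C[C@H](c3ccccc3)NC2=O)ccc1NC(=O)c1ccc(N)cc1` has not yet been measured. It differs from compound 2 by 4-aminophenyl in place of isobutoxy on a carbonyl carbon. Going by the values given here, no measured step speaks to this change: the one step known only lengthens the alkyl chain on the oxygen, whereas here the oxygen itself is removed and an aromatic ring bearing an amine takes its place. That known step stayed within the scatter, but it gives no guide to a change of this kind, so the expectation is uncertain. Compound 3 is estimated at 100 nM, with a range from 30 nM to 400 nM. The expected step of a 1.3-fold higher number from compound 2 to compound 3 (0.10 log units; within the scatter) is therefore small, with no direction claimed beyond the scatter.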

Compound 3, half-maximal inhibitory concentration: 670 nM
Compound 3: the middle estimate sits 6.7-fold (0.83 log units) below what was measured, outside the stated range (above it).
By their numbers in this assay, from the lowest: compounds 1 and 2 (each within the scatter of the next); then compound 3.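

The carbonyl carbon is not indifferent to what it carries in this assay. Isopropyl and isobutyl on the oxygen could not be told apart, but putting 4-aminophenyl in place of isobutoxy gives an 8.4-fold higher number from compound 2 to compound 3 (0.92 log units; beyond the scatter) and putting it in place of isopropoxy gives an 11-fold higher number from compound 1 to compound 3 (1.05 log units; beyond the scatter), so both steps lie beyond the scatter and this replacement goes with a weaker result against either alkoxy partner. No supporting data bear on this shift, so the reason for it remains unknown.

Compound 3 removes the oxygen and brings in both an aromatic ring and an amine in a single change, so these compounds cannot show which of those parts goes with the higher number. A plain phenyl group on the same carbonyl carbon would test the ring without the amine, and a benzyloxy group would test an aromatic ring with the oxygen kept in place.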